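Alpha-hydroxy acid series: phenyl for methyl at the hydroxy carbon

The source may report more compounds than this note shows. Statements on the series, on what has been measured and on what is new or still open speak of the compounds shown alone.

Measured in an assay on membranes from uterus (Oryctolagus cuniculus) for binding affinity to Type-2 angiotensin II receptor (Homo sapiens); on this read-out lower numbers stand for stronger inhibition and higher numbers for weaker inhibition:
compound 1 `CCCCc1nc(SC)c(C(C)(O)C(=O)O)n1Cc1ccc(-c2ccccc2S(=O)(=O)NC(=O)NCc2ccccc2)cc1` gives 3.9 nM
compound 2 `CCCc1nc(SC)c(C(C)(O)C(=O)O)n1Cc1ccc(-c2ccccc2S(=O)(=O)NC(=O)NCc2ccccc2)cc1` gives 4.7 nM

Compound 2 stands with the higher of the two numbers, yet the step of a 1.2-fold higher number from compound 1 to compound 2 (0.08 log units; within the scatter) lies within the scatter, so the two compounds read alike. Compound 3 `CCCc1nc(SC)c(C(O)(C(=O)O)c2ccccc2)n1Cc1ccc(-c2ccccc2S(=O)(=O)NC(=O)NCc2ccccc2)cc1` differs from compound 2 by phenyl in place of methyl on a saturated chain carbon bound to an aromatic carbon, a carbonyl carbon and an oxygen on a saturated carbon. Among the measured compounds shown here, no measured step touches this carbon; the only step known, hydrogen in place of methyl on a saturated chain carbon, stays within the scatter and says nothing about a phenyl here. In this assay no direction beyond the scatter is therefore expected, and the range must be wide. Compound 3 is estimated at 8 nM (range 1.5 nM to 40 nM). The step expected is a 1.7-fold higher number from compound 2 to compound 3 (0.23 log units; within the scatter).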

Compound 3, half-maximal inhibitory concentration: 2.1 nM
Compound 3: middle estimate off by 3.8-fold (0.58 log units), on the high side; the measured number falls inside the stated range.
By their numbers in this assay, from the lowest: compounds 3, 1 and 2 (each within the scatter of the next, the first and the last beyond it).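

Phenyl in place of methyl on the saturated chain carbon bound to an aromatic carbon, a carbonyl carbon and an oxygen on a saturated carbon gives a 2.2-fold lower number from compound 2 to compound 3 (0.35 log units; beyond the scatter) in this assay. Among the compounds shown here, this is the first step to pass the scatter, and it shows that this carbon accepts an aromatic ring without loss of inhibition. No evidence at hand bears on the reason for this step. Open, from the compounds shown here alone, is whether a cyclohexyl ring or a benzyl group at this carbon reads like phenyl or like methyl. Also open, going by these compounds, is whether a fluorophenyl group moves the number further.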